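The source may report more compounds than this note shows. Statements on the series, on what has been measured and on what is new or still open speak of the compounds shown alone.

Measured compounds:
compound 1, `CC1(C)SC(c2cc(Cl)ccc2N)=NN1C(=O)C1CCCCC1`, 7.61%
compound 2, `CCCCC(=O)N1N=C(c2ccccc2N)SC1(C)C`, 39.1%

Among the measured compounds shown here, in an assay on isolated protein for inhibition of Nitric oxide synthase, inducible (Homo sapiens), read by scintillation counting, with a stated time of 30 min, tested at 50 uM (a lower number here means less inhibition, a higher number more inhibition at the concentration tested (going by the name of the read-out)), compound 2 gives 39.1%, the higher of the two numbers measured so far. Its nearest neighbour on this scale is compound 1, which in this assay gives 7.61%, a number well beyond the usual scatter below that of compound 2. For the measured compounds named here, no pair of measured compounds differs in only one place, so these two values say nothing yet about the effect of any single change.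

Compound 3, `CC1(C)SC(c2ccccc2N)=NN1C(=O)C1CCCCC1`, has not been measured. It differs from compound 2 in one place: cyclohexyl in place of butyl on a carbonyl carbon. Going by the values given here, there is no measured step of this kind to lean on. Among the compounds with values here, the only hint is that compound 1, which also carries a cyclohexyl on its carbonyl, shows the low value of 7.61%, but compound 1 differs from compound 3 elsewhere too, so that value cannot be read as the effect of this change alone.

Compound 3 is therefore expected to lose some inhibition relative to compound 2, with the step from a number 14.1 percentage points lower from compound 2 to compound 3 (beyond the scatter) estimated to fall near the edge of the scatter rather than clearly beyond it. For compound 3 the expected value in this assay is 25%, with a likely range from 5% to 50%.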

Compound 3, a percentage reported as inhibition, at one concentration (the size of the read-out at that concentration, not a potency): 28%
Beside the measured number, compound 3's estimate is 3 percentage points below it; the range from low to high includes it.
By their numbers in this assay, from the lowest: compound 1; then compound 3; then compound 2.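

In this assay, among the compounds shown here, the first measured change at this position, cyclohexyl in place of butyl on a carbonyl carbon, gives a number 11.1 percentage points lower from compound 2 to compound 3 (beyond the scatter), so the ring lowers the reading without abolishing inhibition. The second step, hydrogen in place of chloro on an aromatic carbon, gives a number 20.4 percentage points higher from compound 1 to compound 3 (beyond the scatter), which shows that cyclohexyl alone does not set the low reading of compound 1, since removing the chloro raises the number while the cyclohexyl stays in place. Nothing available explains why either change moves the reading in the direction it does.

A single pair cannot tell whether the drop at the carbonyl carbon goes with the ring itself or with the larger group, and a phenyl ring or a longer chain such as hexyl in the same place would help to separate the two. On these data alone, it also remains open whether the chloro would lower the reading in the same way alongside butyl, and how a methoxy group or an amine on that aromatic carbon would compare with hydrogen.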